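A few compounds are considered here, and "the series" means these few. Any claim that something is new, unique, unknown or untested is made for them only; others in the source may bear on it.

- Compound 1 `Cc1c(C(=O)N/N=C\c2ccccc2C(F)(F)F)oc2cccc(O)c12`: 26200 nM
- Compound 2 `Cc1c(C(=O)N/N=C\c2cccc(F)c2O)oc2cccc(O)c12`: 12700 nM

In a functional assay on PC-3 cells (Homo sapiens) for inhibition (a lower number here means a stronger inhibitor, a higher number a weaker inhibitor), compound 2 has the lower of the two numbers, and its gap to compound 1 lies beyond the usual scatter. Compound 3 `COc1ccccc1/C=N\NC(=O)c1oc2cccc(O)c2c1C` carries 2-methoxyphenyl in place of 3-fluoro-2-hydroxyphenyl on a carbon with a double bond to nitrogen. Within the data shown here, no measured pair isolates this change, so the only guide is the range from compound 2 at 12700 nM to compound 1 at 26200 nM. A small move towards weaker inhibition in this assay is expected, namely a 1.5-fold higher number from compound 2 to compound 3 (0.17 log units; within the scatter). The estimate for compound 3 is 19000 nM, with an expected range of 8000 nM to 45000 nM.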

Compound 3, half-maximal inhibitory concentration: 32700 nM
Estimate against measurement, compound 3: 1.7-fold (0.24 log units) below; the measured number falls inside the stated range.
By their numbers in this assay, from the lowest: compound 2; then compounds 1 and 3 (each within the scatter of the next).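

In this assay, 2-methoxyphenyl in place of 3-fluoro-2-hydroxyphenyl gives a 2.6-fold higher number from compound 2 to compound 3 (0.41 log units; beyond the scatter), so the group on this carbon with a double bond to nitrogen can shift the result, and this change removes a hydrogen-bond donor. Methoxy in place of trifluoromethyl on an aromatic carbon gives a 1.2-fold higher number from compound 1 to compound 3 (0.10 log units; within the scatter), so these two groups cannot be told apart here. Nothing measured accounts for either step.

On these data alone, compound 2 and compound 3 differ in more than one feature, so the separate roles of the fluoro and hydroxy groups remain open. As far as these compounds go, how an amine or a carboxylic acid on this ring would behave also remains open.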